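The source may hold more compounds than are shown below. What is called first, only, known or untested is meant among the compounds shown, and "the series" means these compounds.

The series rests on a shared core and differs only in fluoro substitution on aromatic carbons. Compound 1 `CN(C)c1ccc(C#Cc2ccccc2)cc1` is the unsubstituted parent. In a functional assay on LS174T cells (Homo sapiens) for antiproliferative activity, with a stated time of 4 days (a lower number here means a stronger inhibitor, a higher number a weaker inhibitor), compound 1 gives > 3000 nM, which is a limit of the assay and not a number. Compound 2 `CN(C)c1ccc(C#Cc2ccccc2F)cc1` carries fluoro in place of hydrogen on an aromatic carbon, and in this assay compound 2 gives 39 nM. Compound 3 `CN(C)c1ccc(C#Cc2ccc(F)cc2)cc1` carries fluoro on a different aromatic carbon. In this assay compound 3 gives > 3000 nM, again a limit of the assay and not a number. Compound 3 therefore stands at the limit of > 3000 nM in this assay, at which 2 of the 3 values shown sit, and its potency is known only as a limit. The measured steps are an at least 76-fold lower number from compound 1 to compound 2 (1.88 log units; beyond the scatter) and a step that the two limits leave unreadable from compound 1 to compound 3.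

Compound 4 `CN(C)c1ccc(C#Cc2ccc(F)cc2F)cc1` differs from compound 3 by fluoro in place of hydrogen on an aromatic carbon. The same kind of change gave the step of an at least 76-fold lower number from compound 1 to compound 2 (1.88 log units; beyond the scatter), so a large step downward in this assay is expected, an at least 50-fold lower number from compound 3 to compound 4 (1.69 log units; beyond the scatter). Compound 4 is accordingly estimated at 60 nM, with a range from 15 nM to 400 nM.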

Compound 4, half-maximal inhibitory concentration: 56 nM
Compound 4: the middle estimate sits 1.1-fold (0.03 log units) above what was measured; the measured number falls inside the stated range.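

Fluoro in place of hydrogen on an aromatic carbon ortho to a large group now gives a large step in this assay on a second core, an at least 53-fold lower number from compound 3 to compound 4 (1.72 log units; beyond the scatter). The change therefore no longer rests on a single pair of compounds: the same change on two cores in this assay, an at least 76-fold lower number (1.88 log units; beyond the scatter) from compound 1 to compound 2 and an at least 53-fold lower number (1.72 log units; beyond the scatter) from compound 3 to compound 4; the limit leaves it open whether they differ A further fluoro group meta to the first leaves the numbers within the scatter, a 1.4-fold higher number from compound 2 to compound 4 (0.16 log units; within the scatter), so in these four compounds the activity goes with the fluoro group ortho to a large group, and no compound shown goes against this.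

Going by these compounds, the true size of each large step stays open, as compound 1 and compound 3 are known only as limits. Also open, on these data alone, is whether a chlorine atom, a methyl group or a methoxy group at this place would give a step of this kind.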